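Trimming methoxy groups from a diaminoquinoxaline series

A few compounds are considered here, and "the series" means these few. Any claim that something is new, unique, unknown or untested is made for them only; others in the source may bear on it.

Measured so far:
- compound 1, `COc1cc(CNc2nc3cc(N)cc(N)c3nc2-c2ccccc2)cc(OC)c1OC`: 27500 nM
- compound 2, `COc1ccc(CNc2nc3cc(N)cc(N)c3nc2-c2ccccc2)cc1OC`: 55000 nM

Both compounds were tested in a functional assay on UACC-257 cells (Homo sapiens) for inhibition, read by sulforhodamine B assay, with a stated time of 48 h; a lower number here means that less compound is tolerated, a higher number that more compound is tolerated. Compound 1 gives 27500 nM and compound 2 gives 55000 nM; these two numbers sit within the scatter of each other, as the step of a 2.0-fold higher number from compound 1 to compound 2 (0.30 log units; within the scatter) shows, so compound 2 cannot be called different from compound 1 on this evidence.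

Compound 3, `COc1ccc(CNc2nc3cc(N)cc(N)c3nc2-c2ccccc2)cc1`, has not been measured. It differs from compound 2 by hydrogen in place of methoxy on an aromatic carbon.

Among the measured compounds shown here, the only step that bears on this change is a 2.0-fold higher number from compound 1 to compound 2 (0.30 log units; within the scatter), which also removed one methoxy group and stayed within the scatter. The same kind of step is therefore expected again: little or no change beyond the scatter, perhaps a slightly higher number.

Compound 3 is expected to give 70000 nM, most likely between 30000 nM and 160000 nM, which means an estimated step of a 1.3-fold higher number from compound 2 to compound 3 (0.10 log units; within the scatter).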

Compound 3, concentration lethal to 50% of the cells: 56200 nM
For compound 3 the middle estimate is 1.2-fold (0.10 log units) above the measured one, and the stated range covers the measured number.
By their numbers in this assay, from the lowest: compounds 1, 2 and 3 (each within the scatter of the next, the first and the last beyond it).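

In this assay the change from 3,4-dimethoxyphenyl to 4-methoxyphenyl gives a 1.0-fold higher number from compound 2 to compound 3 (0.01 log units; within the scatter) and so cannot be told apart from the scatter. Among the compounds shown here, the earlier step showed this for only one methoxy group, whereas the series now holds two single removals, each within the scatter, so this methoxy group ortho to another methoxy group can also be replaced by hydrogen without a measurable difference in this cell test. Nothing available explains why this replacement leaves the number so little altered.

From the compounds shown here alone, it remains open whether the last methoxy group on this ring can also give way to hydrogen. Going by these compounds, it is also open whether a different group at the same place, such as an amine or a carboxylic acid, would give a step beyond the scatter.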